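A few compounds are considered here, and "the series" means these few. Any claim that something is new, unique, unknown or untested is made for them only; others in the source may bear on it.

Compound 3 `O=c1cc(-c2ccccc2)oc2ccc(OCCCCCCN3CCC(O)CC3)cc12` stands at the lowest number of the three measured here: in an assay on isolated protein (Cavia porcellus) with Sigma non-opioid intracellular receptor 1 (Homo sapiens) as the target, read by radioligand binding (a lower number here means a stronger inhibitor, a higher number a weaker inhibitor), compound 3 gives 100 nM. Compound 2 `CN(C)CCCCCCOc1ccc2oc(-c3ccccc3)cc(=O)c2c1` gives 432 nM in this assay, and compound 1 `CN(C)CCCCOc1ccc2oc(-c3ccccc3)cc(=O)c2c1` gives 720 nM. All steps among these measured compounds change the nitrogen-bearing end of the chain: a 1.7-fold lower number from compound 1 to compound 2 (0.22 log units; within the scatter), a 7.2-fold lower number from compound 1 to compound 3 (0.86 log units; beyond the scatter) and a 4.3-fold lower number from compound 2 to compound 3 (0.64 log units; beyond the scatter). Compound 4 `O=c1cc(-c2ccccc2Cl)oc2ccc(OCCCCCCN3CCC(O)CC3)cc12` differs from compound 3 elsewhere: chloro in place of hydrogen on an aromatic carbon, on an aromatic carbon of a six-membered aromatic ring of carbon only, ortho to a large group; read one bond further out, phenyl becomes 2-chlorophenyl. Going by the values given here, none of the measured steps touches this ring, so no step in this assay bears directly on the change; the only measured steps concern the chain end and are within the scatter or modest, while the phenyl ring has been held unchanged in compounds 1, 2 and 3. Among the compounds with values here, with no direct precedent, the expected step from compound 3 to compound 4 in this assay is small and may not exceed the scatter, a 1.1-fold lower number from compound 3 to compound 4 (0.05 log units; within the scatter). Compound 4 is therefore estimated at 90 nM in this assay, with a range from 30 nM to 300 nM.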

Compound 4, half-maximal inhibitory concentration: 47 nM
Compound 4: middle estimate off by 1.9-fold (0.28 log units), on the high side, and the stated range covers the measured number.
By their numbers in this assay, from the lowest: compound 4; then compound 3; then compounds 2 and 1 (each within the scatter of the next).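

In this assay chloro in place of hydrogen, with phenyl becoming 2-chlorophenyl, gives a 2.1-fold lower number from compound 3 to compound 4 (0.33 log units; beyond the scatter) and so shows a modest gain beyond the scatter from a change away from the nitrogen-bearing end of the chain. Compounds 1, 2 and 3 all carry the same unsubstituted phenyl and could say nothing about this ring; compound 4 shows that this aromatic carbon, ortho to a large group, accepts a chlorine without loss in this measure and that the ring can contribute to the number alongside the 4-hydroxypiperidin-1-yl chain end. No measurement shown here accounts for the step, so its origin remains unexplained.

From the compounds shown here alone, it remains open whether fluoro, bromo, methyl or methoxy on this same aromatic carbon would give a step of similar size, or whether chloro on another carbon of the ring would do the same. Going by these compounds, it is also open whether 2-chlorophenyl would lower the number to a similar degree when paired with the dimethylamino chain ends of compound 1 and compound 2, or with a morpholine or piperazine at the end of the chain.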